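Swapping hydroxy for amino to reach compound 4

The source may report more compounds than this note shows. Statements on the series, on what has been measured and on what is new or still open speak of the compounds shown alone.

Measured compounds:
compound 1 `COc1ccc(/C=C(/F)c2cc(OC)c(OC)c(OC)c2)cc1O` at 1.1 nM
compound 2 `COc1ccc(/C=C(/F)c2cc(OC)c(OC)c(OC)c2)cc1N` at 2.4 nM
compound 3 `COc1ccc(/C(F)=C\c2cc(OC)c(OC)c(OC)c2)cc1O` at 4 nM

All three compounds were tested in a functional assay on NCI-H460 cells (Homo sapiens) for cytotoxicity, read by sulforhodamine B assay, with a stated time of 72 h (a higher number here means a weaker inhibitor, a lower number a stronger inhibitor), and all gave low numbers. Compound 3 at 4 nM sits within the scatter of compound 2 at 2.4 nM and thus cannot be separated from it. Compound 1 at 1.1 nM shows a lower number than compound 3.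

Compound 4 `COc1ccc(/C(F)=C\c2cc(OC)c(OC)c(OC)c2)cc1N` is made from compound 3 by a single exchange, amino in place of hydroxy on an aromatic carbon, ortho to a methoxy group and meta to a large group (amino in place of hydroxy on an aromatic carbon). Among the compounds with values here, only one measured step bears on this exchange. It is the same swap made on the isomeric arrangement of the shared core, a 2.2-fold higher number from compound 1 to compound 2 (0.34 log units; beyond the scatter), and it is modest. This single pair is the whole of the evidence, and the data do not show whether the step carries over to the other arrangement. A step of similar modest size towards a higher number is therefore expected, with the estimate in this assay being a 2.1-fold higher number from compound 3 to compound 4 (0.33 log units; beyond the scatter) as the likely outcome. Compound 4 is estimated at 8.5 nM with an expected range of 3.5 nM to 20 nM on present evidence.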

Compound 4, half-maximal inhibitory concentration: 11.5 nM
Estimate against measurement, compound 4: 1.4-fold (0.13 log units) below, and the stated range covers the measured number.
By their numbers in this assay, from the lowest: compound 1; then compounds 2 and 3 (each within the scatter of the next); then compound 4.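

In this assay, the exchange of hydroxy for amino on this aromatic carbon, ortho to a methoxy group, gives a 2.9-fold higher number from compound 3 to compound 4 (0.46 log units; beyond the scatter). The earlier compounds shown here showed this change on only one arrangement of the shared core, but it can now be read on two, and the steps run the same way and match in size: the same change on two cores in this assay, a 2.2-fold higher number (0.34 log units; beyond the scatter) from compound 1 to compound 2 and a 2.9-fold higher number (0.46 log units; beyond the scatter) from compound 3 to compound 4, 1.3-fold (0.12 log units) apart, within the scatter of two such steps. Across these two pairs the hydroxy compound gives the lower number each time, so the modest step carries over between the two arrangements and does not depend on which of them bears the change.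

The compounds shown carry only hydroxy and amino at this position, which leaves open what a plain hydrogen, a dimethylamino group or an acetamide would give on either arrangement. They also do not tell why amino gives the higher number in both pairs, or whether the same step would appear in cells other than those of this assay.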